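The source may report more compounds than this note shows. Statements on the series, on what has been measured and on what is new or still open speak of the compounds shown alone.

Working notes on the series. Within the data shown here, compound 2 `CCCn1c(=O)[nH]c2nc(-c3ccc(S(=O)(=O)N4CCN(C(C)c5ccccc5)CC4)cc3)[nH]c2c1=O` in an assay on CHO cells for displacement of a labelled ligand from adenosine receptor A1 (Homo sapiens), read by scintillation counting, with a stated time of 90 min, tested at 1 uM, in the presence of a further agent that is not named here (on this read-out higher numbers stand for more inhibition at the one concentration tested (going by the name of the read-out) and lower numbers for less inhibition), gives 42%, the highest of the two numbers so far; its nearest neighbour, compound 1 `CCCn1c(=O)[nH]c2nc(-c3ccc(S(=O)(=O)N4CCN(c5ccc(Cl)cc5F)CC4)cc3)[nH]c2c1=O`, gives in this assay 9%. Among the measured compounds shown here, the one measured step, a number 33 percentage points higher from compound 1 to compound 2 (beyond the scatter), bears on the present change (4-bromobenzyl in place of 1-phenylethyl on an amine nitrogen in a ring), which yields compound 3 `CCCn1c(=O)[nH]c2nc(-c3ccc(S(=O)(=O)N4CCN(Cc5ccc(Br)cc5)CC4)cc3)[nH]c2c1=O`. That change swaps 1-phenylethyl for 4-bromobenzyl and does not return to the 4-chloro-2-fluorophenyl of compound 1, so no step beyond the scatter is expected, a number 4 percentage points lower from compound 2 to compound 3 (within the scatter). Compound 3 is estimated at 38%, expected to lie between 20% and 58%.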

Compound 3, a percentage reported as inhibition, at one concentration (the size of the read-out at that concentration, not a potency): 31%
For compound 3 the middle estimate is 7 percentage points above the measured one, within the range that was stated.
By their numbers in this assay, from the lowest: compound 1; then compound 3; then compound 2.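

At the amine nitrogen in the ring, this assay separates 1-phenylethyl from 4-bromobenzyl, two groups with the same count of heavy atoms, with a number 11 percentage points lower from compound 2 to compound 3 (beyond the scatter) as the result. The other step, a number 22 percentage points higher from compound 1 to compound 3 (beyond the scatter), shows that a higher number than that of the 4-chloro-2-fluorophenyl group is not confined to 1-phenylethyl. No measurement at hand accounts for either step.

The step from 1-phenylethyl to 4-bromobenzyl both removes a methyl and adds a bromine, and the compounds shown do not separate the two. Plain benzyl would bear on this, and a carboxylic acid or an amine on the aromatic ring remains open.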